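A Dimethoxy Swap Without a Measured Starting Point

The compounds below may be only part of what the source reports. "The series", "measured", "known", "first", "only" and "open" are said of these compounds alone.

In a functional assay on HeLa cells (Homo sapiens) for cytotoxicity, read by MTT assay, with a stated time of 72 h (a higher number here means a weaker inhibitor, a lower number a stronger inhibitor), compound 3 `N#Cc1ccc(/C=C/C(=O)Nc2cc3c(Nc4ccc(F)c(Cl)c4)ncnc3cc2O[C@H]2CCOC2)cc1` has no number to stand on: its result reads "not determined" (no result reported). Going to compound 4 `COc1ccc(OC)c(/C=C/C(=O)Nc2cc3c(Nc4ccc(F)c(Cl)c4)ncnc3cc2O[C@H]2CCOC2)c1` makes the change (2,5-dimethoxyphenyl in place of 4-cyanophenyl on a double-bonded chain carbon bound to a double-bonded chain carbon), placing 2,5-dimethoxyphenyl where 4-cyanophenyl sat. With no starting value, no step size can be expected from compound 3, so the estimate must rest on related compounds. Compound 1 `COc1ccc(/C=C/C(=O)Nc2cc3c(Nc4ccc(F)c(Cl)c4)ncnc3cc2O[C@H]2CCOC2)c(OC)c1` gives 26500 nM, and compound 2 `COc1cc(/C=C/C(=O)Nc2cc3c(Nc4ccc(F)c(Cl)c4)ncnc3cc2O[C@H]2CCOC2)cc(OC)c1OC` gives 24500 nM. Among the compounds with values here, the only measured step, a 1.1-fold lower number from compound 1 to compound 2 (0.03 log units; within the scatter), stays within the scatter, so swapping these methoxy-bearing groups barely moved the number in this one pair. Compound 4 is therefore expected to fall in the same region. For compound 4 the estimated value is 25000 nM, with an expected range from 12000 nM to 50000 nM.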

Compound 4, half-maximal inhibitory concentration: 26800 nM
Beside the measured number, compound 4's estimate is 1.1-fold (0.03 log units) below it, within the range that was stated.
By their numbers in this assay, from the lowest: compounds 2, 1 and 4 (each within the scatter of the next).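

In this assay, the 2,5-dimethoxyphenyl group of compound 4 reads like the two other methoxy-bearing phenyl groups at this place (a 1.0-fold higher number from compound 1 to compound 4 (0.00 log units; within the scatter)) (a 1.1-fold higher number from compound 2 to compound 4 (0.04 log units; within the scatter)). So for compounds 1, 2 and 4, three different methoxy patterns leave the number unmoved, while the step away from the 4-cyanophenyl group of compound 3 cannot be read. No measurement offered here explains this flat result.

Still open, as far as these compounds go, is whether any other kind of group at this place would shift the number. A phenyl ring carrying an amine or a carboxylic acid would test that.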